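Swapping a Urea for an Amide on a Shared Core

This account rests on a few compounds, and the source may have more. Where it says the series, first, only, none or still open, it means among the compounds named here.

Compound 1 has the structure `O=C(Nc1ccc(-n2ccc3nc(C(=O)NCc4ccccc4)ccc32)cc1)Nc1ccc(Cl)c(C(F)(F)F)c1`. In a functional assay on A375P cells (Homo sapiens) for cytotoxicity, read by MTT assay (a lower number here means a stronger inhibitor, a higher number a weaker inhibitor), compound 1 gives 1100 nM, the lowest of the three numbers measured here. Compound 3, with the structure `NC(=O)c1ccc2c(ccn2-c2ccc(NC(=O)Nc3ccc(Cl)c(Cl)c3)cc2)n1`, gives 3200 nM, a gap from compound 1 that lies beyond the scatter. Compound 2, with the structure `COC(=O)c1ccc2c(ccn2-c2ccc(NC(=O)c3cccc(C(F)(F)F)c3)cc2)n1`, gives 9500 nM, the highest number of the three and further still from compound 1. Among the compounds with values here, compound 2 is the only measured compound that carries an amide rather than a urea, but it also differs from compound 1 elsewhere, so what its value shows cannot be tied to one change.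

The unmeasured compound 4 has the structure `O=C(Nc1ccc(-n2ccc3nc(C(=O)NCc4ccccc4)ccc32)cc1)c1ccc(Cl)c(C(F)(F)F)c1`. It differs from compound 1 in a single place: 4-chloro-3-(trifluoromethyl)phenyl in place of (4-chloro-3-(trifluoromethyl)phenyl)amino on a carbonyl carbon. The carbonyl then bonds directly to the ring, and the urea becomes an amide. Within the data shown here, no measured pair differs only in this way, so the size of the step is open. The one amide measured, compound 2, gives 9500 nM, which points toward a weaker inhibitor. A modest step in that direction, beyond the scatter, is expected, a 2.7-fold higher number from compound 1 to compound 4 (0.44 log units; beyond the scatter). Compound 4 is therefore estimated at 3000 nM, with a range from 1000 nM to 9000 nM.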

Compound 4, half-maximal inhibitory concentration: 700 nM
For compound 4 the middle estimate is 4.3-fold (0.63 log units) above the measured one, and the stated range ends above it.
By their numbers in this assay, from the lowest: compounds 4 and 1 (each within the scatter of the next); then compound 3; then compound 2.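

Within the data shown here, compound 1 and compound 4 are the first pair here that differ in one place only, which makes it possible to read this change on its own. In this assay, putting 4-chloro-3-(trifluoromethyl)phenyl in place of (4-chloro-3-(trifluoromethyl)phenyl)amino on the carbonyl carbon gives a 1.6-fold lower number from compound 1 to compound 4 (0.20 log units; within the scatter) and so leaves the reading effectively unchanged. The group that leaves carries one hydrogen-bond donor and the group that enters carries none, so in this pair the urea nitrogen and its hydrogen are not needed for a number in this range, and turning the urea into an amide costs nothing that this assay can detect. No measurement is available to explain why the two compounds read so closely.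

This single pair cannot show whether the urea and the amide would also match on a core carrying a different group in place of the benzyl amide, such as a carboxylic acid. It also leaves open how a different link at the same place, such as a sulfonamide, would read in this assay.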